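The compounds below may be only part of what the source reports. "The series", "measured", "known", "first", "only" and "open" are said of these compounds alone.

Compound 1 `N#Cc1cc(F)cc(C#Cc2cccc(F)n2)c1` gives 41 nM in an assay on membranes from brain (strain Sprague-Dawley) for displacement of a labelled ligand from metabotropic glutamate receptor 5 (Rattus norvegicus), read by scintillation counting, with a stated time of 60 min (a higher number here means a weaker inhibitor, a lower number a stronger inhibitor), the lowest of the two numbers recorded. Its nearest neighbour is compound 2 `N#Cc1cccc(C#Cc2cccc(F)n2)c1`, which in this assay gives 150 nM; the step of a 3.7-fold higher number from compound 1 to compound 2 (0.56 log units; beyond the scatter) exchanges a fluoro on the shared core for hydrogen. Compound 3 `N#Cc1cncc(C#Cc2cccc(CO)n2)c1` in this assay sits at a limit, > 10000 nM, and that is the limit of > 10000 nM in this assay, at which 1 of the 3 values shown sits. Compound 4 `N#Cc1cc(F)cc(C#Cc2cccc(C#N)n2)c1` is not yet measured; it differs from compound 1 by cyano in place of fluoro on an aromatic carbon, a cyano in place of the fluoro on the six-membered aromatic ring with one nitrogen, next to the ring nitrogen. Among the measured compounds shown here, no measured step touches this position: the only step recorded, a 3.7-fold higher number from compound 1 to compound 2 (0.56 log units; beyond the scatter), concerns the other ring, and compound 3 differs from compound 1 in two places at once. The expectation for compound 4 therefore leans on the modest size of a 3.7-fold higher number from compound 1 to compound 2 (0.56 log units; beyond the scatter). Compound 4 is expected to give 80 nM in this assay, between 20 nM and 400 nM. That estimate means a step of a 2.0-fold higher number from compound 1 to compound 4 (0.29 log units; within the scatter), expected to be small or within the scatter.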

Compound 4, inhibition constant: 2.7 nM
For compound 4 the middle estimate is 30-fold (1.47 log units) above the measured one; measured number below the stated range.
By their numbers in this assay, from the lowest: compound 4; then compound 1; then compound 2. At a limit, above all of these: compound 3.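

At this position, on an aromatic carbon next to the ring nitrogen, the core of compound 1 proves highly responsive in this assay: cyano in place of fluoro gives a 15-fold lower number from compound 1 to compound 4 (1.18 log units; beyond the scatter). This large step shows that the position tolerates the two-atom cyano and that a change here can move the number further than the modest exchange on the other ring, a 3.7-fold higher number from compound 1 to compound 2 (0.56 log units; beyond the scatter). No measurement shown here accounts for the size of this step.

From the compounds shown here alone, only fluoro and cyano can be compared directly at this position, so it remains open how an amine, a methyl or a carboxylic acid there would read. Going by these compounds, it also remains open whether cyano would produce a step of similar size on the core of compound 2, which carries hydrogen in place of the fluoro on the other ring.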